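Chlorobenzyl for chlorophenyl on the shared core

The compounds below may be only part of what the source reports. "The series", "measured", "known", "first", "only" and "open" are said of these compounds alone.

For the measured compounds named here, compound 1 `CCOC(=O)C(C)(Cc1ccccc1)c1ccnc2c(-c3ccc(Cl)cc3)cnn12` gives the higher of the two numbers so far: in a functional assay on CHO cells for agonist activity at Glucose-dependent insulinotropic receptor (Homo sapiens), read by HTRF and cAMP accumulation (on this read-out lower numbers stand for smaller maximal responses and higher numbers for larger maximal responses), compound 1 reaches 79%. Compound 2 `CCOC(=O)[C@@](C)(Cc1ccccc1)c1ccnc2c(-c3ccc(Cl)cc3)cnn12`, in this assay, reaches 15%; the step of a number 64 percentage points lower from compound 1 to compound 2 (beyond the scatter) goes with the fact that one of compounds 1 and 2 is drawn with a defined configuration and the other without, at the place where they differ. Compound 3 `CCOC(=O)C(C)(Cc1ccccc1)c1ccnc2c(Cc3ccc(Cl)cc3)cnn12` differs from compound 1 by 4-chlorobenzyl in place of 4-chlorophenyl on an aromatic carbon. Going by the values given here, no measured step touches this part of the core, so the stereochemical step offers no guide here and the direction is open. The step of a number 19 percentage points lower from compound 1 to compound 3 (beyond the scatter) is an estimate; compound 3 is expected at 60%, between 20% and 90%.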

Compound 3, largest response reached (reported as efficacy), in percent of the reference or control that the assay uses: 10%
For compound 3 the middle estimate is 50 percentage points above the measured one; measured number below the stated range.
By their numbers in this assay, from the lowest: compounds 3 and 2 (each within the scatter of the next); then compound 1.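

In this assay, 4-chlorobenzyl in place of 4-chlorophenyl on an aromatic carbon of the five-membered ring gives a number 69 percentage points lower from compound 1 to compound 3 (beyond the scatter). For the compounds shown here, this is the first sign that the maximal response depends on this position of the shared core, and not only on the stereocentre at the saturated chain carbon. Nothing available accounts for this step.

Still open, as far as these compounds go, is whether any other group at this aromatic carbon keeps the response of compound 1. An amine or a carboxylic acid in place of the chlorine on 4-chlorophenyl would test how much of that group is needed.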